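The source may hold more compounds than are shown below. What is called first, only, known or untested is meant among the compounds shown, and "the series" means these compounds.

Measured so far in a functional assay on the whole organism (strain Hartley) for inhibition, with Cavia porcellus as the target, with stated times of 15 min and 2 min (a lower number here means that less compound is needed, a higher number that more compound is needed for the effect), are two compounds:
- compound 1 `CCCCC1([C@@H](O)/C=C/C2CCC(=O)[C@@H]2CCCCCCC(=O)O)CCC1` gives 0.0139 mg/kg 
- compound 2 `CCCCC1([C@H](O)/C=C/C2CCC(=O)[C@@H]2CCCCCC(=O)O)CCC1` gives 0.032 mg/kg 

Compound 2 holds the higher of the two numbers, so more of it is needed for the effect, and its gap to compound 1 lies beyond the scatter. Among the measured compounds shown here, the two compounds do not differ in just one place, so no measured single-place step is available to size the next change.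

Next in this assay is compound 3 `CCCCC1([C@H](O)/C=C/C2CCC(=O)[C@@H]2CCCCSCC(=O)OCC)CCC1`. Compared with compound 2, it carries ((ethoxycarbonyl)methyl)sulfanyl in place of carboxymethyl on a saturated chain carbon, four bonds along the chain from a saturated ring carbon.

For the measured compounds named here, the only anchor for this change is compound 2 (0.032 mg/kg), and the data offer no direct precedent for it. A moderate move toward a higher number is therefore expected, with real uncertainty in both size and direction, and the estimated step is (a 1.9-fold higher number from compound 2 to compound 3 (0.27 log units; within the scatter)). For compound 3 the estimated value is 0.06 mg/kg (expected range 0.015 mg/kg to 0.25 mg/kg).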

Compound 3, dose for half-maximal effect: 0.03 mg/kg
For compound 3 the middle estimate is 2.0-fold (0.30 log units) above the measured one; the range from low to high includes it.
By their numbers in this assay, from the lowest: compound 1; then compounds 3 and 2 (each within the scatter of the next).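

In this assay the change to ((ethoxycarbonyl)methyl)sulfanyl in place of carboxymethyl on a saturated chain carbon, four bonds along the chain from a saturated ring carbon, gives a 1.1-fold lower number from compound 2 to compound 3 (0.03 log units; within the scatter), the first single-place step available for the series. This position therefore tolerates an exchange of a group with 4 heavy atoms and 1 hydrogen-bond donor for one with 7 heavy atoms, including sulfur, and 0 hydrogen-bond donors, with no separable shift in the dose read-out of this whole-organism assay. No supporting measurement is available to explain why the read-out holds across this change.

The step alters the sulfur and the ethyl ester together, so the compounds shown do not separate what each contributes to the result. Open comparisons at this position are the same sulfur-containing chain ending in a free carboxylic acid, which would isolate the ester, and the all-carbon chain ending in an ethyl ester, which would isolate the sulfur.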